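Swapping an Aryl Sulfonyl Cap for a Small Ketone Chain

A few compounds are considered here, and "the series" means these few. Any claim that something is new, unique, unknown or untested is made for them only; others in the source may bear on it.

Of the compounds shown here, two have been measured so far.
Compound 1, `CCN(CC)c1ccc2cc(C(=O)c3ccc(N4CCN(C(=O)CN5CCN(C(=O)CCl)CC5)CC4)cc3)oc2c1`, gives > 40000 nM in a functional assay on MCF7 cells (Homo sapiens) for cytotoxicity, read by MTT assay, with a stated time of 48 h; a lower number here means a stronger inhibitor, a higher number a weaker inhibitor; this is a limit of the assay, not a number.
Compound 2, `CCN(CC)c1ccc2cc(C(=O)c3ccc(N4CCN(C(=O)CN5CCN(S(=O)(=O)c6ccc(F)cc6)CC5)CC4)cc3)oc2c1`, gives 20500 nM in this assay.

Both compounds share the same core and differ only in the group on an amine nitrogen in a ring. For the measured compounds named here, compound 2 holds the only real number in this assay; the other value is a limit, as described by the limit of > 40000 nM in this assay, at which 1 of the 2 values shown sits. Going by the values given here, the step of an at least 1.9-fold lower number from compound 1 to compound 2 (0.29 log units; that floor lies within the scatter) is therefore the single guide, and its floor sits within the scatter, so it shows little beyond a weak result for both compounds.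

Compound 3, `CCN(CC)c1ccc2cc(C(=O)c3ccc(N4CCN(C(=O)CN5CCN(CC(C)=O)CC5)CC4)cc3)oc2c1`, is the next compound. Its change from compound 2 is 2-oxopropyl in place of (4-fluorophenyl)sulfonyl on an amine nitrogen in a ring. Among the compounds with values here, no measured step matches this exact change; the one measured step shows only that a smaller group on this nitrogen gave a limit, while the larger aryl sulfonyl gave a number. Compound 3 is expected to sit weaker than compound 2 by a 1.7-fold higher number from compound 2 to compound 3 (0.23 log units; within the scatter), a step that could itself fall within the scatter. The estimate for compound 3 is 35000 nM, with a range from 15000 nM to 90000 nM.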

Compound 3, half-maximal inhibitory concentration: 11000 nM
The estimate for compound 3 lay 3.2-fold (0.50 log units) above the measured number; measured number outside the range, below it.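

On this ring nitrogen, replacing (4-fluorophenyl)sulfonyl, with its six-membered aromatic ring, by 2-oxopropyl, a chain with no ring, gives a 1.9-fold lower number from compound 2 to compound 3 (0.27 log units; within the scatter) in this assay and so no clear shift. For the compounds shown here, two caps as different as these therefore give values within the scatter of each other, something the earlier pair could not show, since only one of its two values was a number. Going by these compounds alone, replacing (chloromethyl)carbonyl with 2-oxopropyl gives an at least 3.6-fold lower number from compound 1 to compound 3 (0.56 log units; beyond the scatter) as the first step that is clearly beyond the scatter, although its true size stays unknown. Compound 1 has only a limit, not a number: the limit of > 40000 nM in this assay, at which 1 of the 3 values shown sits.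

Going by these compounds, it remains open whether the carbonyl of 2-oxopropyl matters, which a comparison with a plain propyl chain could test, and whether the sulfonyl part of the larger cap counts for anything, which a methylsulfonyl group could test. Also open, on these data alone, is whether an amine or a carboxylic acid at the end of a longer chain on this nitrogen would move the number beyond the scatter from compound 3.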